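This account rests on a few compounds, and the source may have more. Where it says the series, first, only, none or still open, it means among the compounds named here.

Compounds measured so far:
- compound 1, `C=CC(=O)Nc1cccc(Nc2nc(Cl)nc(Nc3ccc(OCCOC)cc3)n2)c1`: "not determined" (no result reported) in a functional assay on Raji cells (Homo sapiens) for antiproliferative activity, read by CCK-8 assay, with a stated time of 24 h; a lower number here means a stronger inhibitor, a higher number a weaker inhibitor
- compound 2, `C=CC(=O)Nc1cccc(Nc2ncnc(Nc3ccc(-c4ccc(C)nc4)cc3)n2)c1`: 13800 nM
- compound 3, `C=CC(=O)Nc1cccc(Nc2ncnc(Nc3ccc(-c4ccc(Cl)nc4)cc3)n2)c1`: "not determined" (no result reported)

Among the compounds with values here, compound 1 has no number of its own in this assay, and compound 3 likewise has none, so the only value in hand comes from compound 2, which shares the same core and the same acrylamide arm but carries a different group at the far end. Compound 4, `C=CC(=O)Nc1cccc(Nc2ncnc(Nc3ccc(OCCOC)cc3)n2)c1`, is the next compound to be tested. It differs from compound 1 in one place: hydrogen in place of chloro on an aromatic carbon. Within the data shown here, no pair of measured compounds shows what this change does, so the size of the step in this assay cannot be read from data here; with no numbers on either side, neither a direction nor a magnitude beyond the scatter can be claimed. The nearest guide is compound 2, whose weak value in this assay suggests that compounds of this core land in the high range. Compound 4 is therefore expected to give about 12000 nM, estimated to lie anywhere from 2500 nM to 60000 nM.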

Compound 4, half-maximal inhibitory concentration: 105000 nM
Estimate against measurement, compound 4: 8.8-fold (0.94 log units) below, and the stated range ends below it.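

The step from chloro to hydrogen cannot be read: compound 1 has no number in this assay, so there is nothing to set compound 4 against. Within the data shown here, the result does give a first comparison at the far end of the molecule, where both compounds carry hydrogen on the aromatic carbon: 2-methoxyethoxy in place of 6-methylpyridin-3-yl gives a 7.6-fold higher number from compound 2 to compound 4 (0.88 log units; beyond the scatter) and so a weaker inhibitor, which shows that the group at this end matters in this test. Nothing measured here explains that difference.

From the compounds shown here alone, whether chloro on the carbon between two ring nitrogen atoms raises or lowers the number stays open, as does the effect of a methyl group or an amine there. At the far end, a chain longer than 2-methoxyethoxy or a carboxylic acid could fall on either side of these two compounds.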